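This account rests on a few compounds, and the source may have more. Where it says the series, first, only, none or still open, it means among the compounds named here.

Working notes on the series. Three compounds have numbers in a functional assay on DLD-1 cells (Homo sapiens) for antiproliferative activity, read by CellTiter-Glo, with a stated time of 72 h; a higher number here means a weaker inhibitor, a lower number a stronger inhibitor. Compound 1, `Cc1cc(C)c(S(=O)(=O)N2CCC(C3OCC(C)CO3)CC2)c(C)c1`, gives only a limit in this assay, > 5000 nM; this is the assay limit of > 5000 nM in this assay, at which 1 of the 3 values shown sits, and not a measured number. Compound 2, `CC1CCN(C2CCN(S(=O)(=O)c3cccc(-c4ccccc4F)c3)CC2)CC1`, gives 10 nM in this assay and stands lowest of the two numbers shown. Compound 3, `CC1CCN(C2CCN(S(=O)(=O)c3ccc(C(C)C)cc3)CC2)CC1`, gives 685 nM in this assay, a gap to compound 2 that lies beyond the scatter. Among the compounds with values here, no step between two measured compounds differing in one place is available, so the pair of compound 2 and compound 3 shows only that a biaryl sulfonyl partner sits far below an isopropylphenyl partner.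

Compound 4, `CC1CCN(C2CCN(S(=O)(=O)c3cccc(C(F)(F)F)c3)CC2)CC1`, is not yet measured. It differs from compound 2 by trifluoromethyl in place of 2-fluorophenyl on an aromatic carbon, the new group sitting on an aromatic carbon of a six-membered aromatic ring of carbon only. Within the data shown here, the closest precedent is compound 3, whose value 685 nM sits well above compound 2 with a small non-aromatic substituent. In this assay a step from compound 2 to compound 4 of a 30-fold higher number from compound 2 to compound 4 (1.48 log units; beyond the scatter) is expected, towards a weaker inhibitor and beyond the scatter. Compound 4 is expected to give about 300 nM in this assay, with a range from 80 nM to 1200 nM.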

Compound 4, half-maximal inhibitory concentration: > 5000 nM
Compound 4: only a limit was reported (the forecaster's own chance of this, stated with the estimate: 5%); middle value at least 16-fold (1.22 log units) away from the limit.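

Within the data shown here, the first single-place step falls on an aromatic carbon meta to a large group, and it is large: with trifluoromethyl in place of 2-fluorophenyl, this assay gives an at least 500-fold higher number from compound 2 to compound 4 (2.69 log units; beyond the scatter). The activity of compound 2 therefore depends on the group at this place and is not carried by the shared core alone. The reading for compound 4 is a limit and not a number, so the step gives only a lower bound on the change: the limit of > 5000 nM in this assay, at which 2 of the 4 values shown sit.

The compounds shown leave open whether an aromatic ring at this place is what matters or the particular 2-fluorophenyl group. An unsubstituted phenyl, a pyridyl or a cyclohexyl group in the same place would separate these readings, and intermediate values would then give the step a measured size.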